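A few compounds are considered here, and "the series" means these few. Any claim that something is new, unique, unknown or untested is made for them only; others in the source may bear on it.

Measured so far:
compound 1 `CC1=C(C(=O)Nc2ccc(F)c(Cl)c2)C(c2cccc(Oc3ccccc3)c2)NC(=S)N1`: 17800 nM
compound 2 `CC1=C(C(=O)Nc2ccc(Cl)c(Cl)c2)C(c2cccc(Oc3ccccc3)c2)NC(=S)N1`: 9330 nM
compound 3 `COc1cccc(C2NC(=S)NC(C)=C2C(=O)Nc2ccc(Cl)c(Cl)c2)c1`: 9330 nM

In a functional assay on COLO 205 cells (Homo sapiens) for cytotoxicity, read by sulforhodamine B assay, with a stated time of 48 h (on this read-out lower numbers stand for stronger inhibition of growth and higher numbers for weaker inhibition of growth), compound 2 and compound 3 stand level: no change at the digits printed from compound 2 to compound 3 (within the scatter). The two cores differ by methyl in place of phenyl on an oxygen on an aromatic ring. Compound 1 differs from compound 2 by fluoro in place of chloro on an aromatic carbon, and this gave a 1.9-fold higher number from compound 2 to compound 1 (0.28 log units; within the scatter).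

Compound 4 `COc1cccc(C2NC(=S)NC(C)=C2C(=O)Nc2ccc(F)c(Cl)c2)c1` is not yet measured. It differs from compound 3 by fluoro in place of chloro on an aromatic carbon, which is the same change, at the same place, as that between compound 2 and compound 1. The step is therefore expected to be of like size: a 1.8-fold higher number from compound 3 to compound 4 (0.26 log units; within the scatter), resting on a 1.9-fold higher number from compound 2 to compound 1 (0.28 log units; within the scatter). Going by the values given here, only one earlier instance of the change is known, so the expectation is loose. Compound 4 is expected to give 17000 nM, with a likely range from 8000 nM to 40000 nM.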

Compound 4, concentration for 50% growth inhibition: 26900 nM
For compound 4 the middle estimate is 1.6-fold (0.20 log units) below the measured one; measured number inside the range.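

In this assay, the change from 3,4-dichlorophenyl to 3-chloro-4-fluorophenyl on the core of compound 3 gives a 2.9-fold higher number from compound 3 to compound 4 (0.46 log units; beyond the scatter), and this agrees with the earlier step on the other core: the same change on two cores in this assay, a 1.9-fold higher number (0.28 log units; within the scatter) from compound 2 to compound 1 and a 2.9-fold higher number (0.46 log units; beyond the scatter) from compound 3 to compound 4, 1.5-fold (0.18 log units) apart, within the scatter of two such steps

Methyl in place of phenyl on the oxygen gives a 1.5-fold higher number from compound 1 to compound 4 (0.18 log units; within the scatter), and this change also carries over between the two halogen patterns: the same change on two cores in this assay, no change at the digits printed (within the scatter) from compound 2 to compound 3 and a 1.5-fold higher number (0.18 log units; within the scatter) from compound 1 to compound 4, 1.5-fold (0.18 log units) apart, within the scatter of two such steps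

These two pairs show agreement only across the cores shown; they do not fix one size for either change or show that it holds on any other core.

The compounds shown leave open how an amine or a carboxylic acid on the amide's aromatic ring would read in this assay. On these data alone, a longer chain in place of the methyl on the oxygen is also open.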